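Thiophene for Chlorophenyl on the Alkyne of Compound 2

The compounds below may be only part of what the source reports. "The series", "measured", "known", "first", "only" and "open" are said of these compounds alone.

Compound 1 `Cc1ccc(C#Cc2ccc3c(n2)CCN(C2CCCC2)C3=O)cc1` carries a 4-methylphenyl on a triple-bonded carbon. In an assay on HEK293 cells for displacement of a labelled ligand from metabotropic glutamate receptor 5 (Homo sapiens), with a stated time of 2 h (on this read-out higher numbers stand for weaker inhibition and lower numbers for stronger inhibition), compound 1 returns only a limit of the assay, > 32000 nM. Compound 2 `O=C1c2ccc(C#Cc3ccccc3Cl)nc2CCN1C1CCCC1` has a 2-chlorophenyl in that place. In this assay compound 2 likewise returns only a limit, > 32000 nM. The step that the two limits leave unreadable from compound 1 to compound 2 therefore cannot be read in size or direction. Compound 2 thus stands at the limit of > 32000 nM in this assay, at which 2 of the 2 values shown sit, with no number of its own, and nothing in the measured set shows how far beyond that limit it lies.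

Compound 3 `O=C1c2ccc(C#Cc3cccs3)nc2CCN1C1CCCC1` is obtained by the change (thiophen-2-yl in place of 2-chlorophenyl on a triple-bonded carbon). For the measured compounds named here, no measured step bears directly on this exchange; the only step at hand, from compound 1 to compound 2, is itself unreadable, so no size of step can be drawn from it. The expectation for compound 3 rests only on the fact that both neighbours sit at the limit, and the expected step of an at least 1.0-fold lower number from compound 2 to compound 3 (0.02 log units; that floor lies within the scatter) is accordingly taken as none beyond the scatter. Compound 3 is therefore estimated at 30000 nM in this assay, in a range from 5000 nM to 100000 nM, most likely again reported only as a limit.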

Compound 3, inhibition constant: 2840 nM
Compound 3: middle estimate off by 11-fold (1.02 log units), on the high side; measured number below the stated range.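

For the compounds shown here, with compound 3, this assay yields the first number in this set, showing that the group on a triple-bonded carbon can move the read-out, which the earlier pair could not show since the step between compound 1 and compound 2 cannot be read. Thiophen-2-yl in place of 2-chlorophenyl gives an at least 11-fold lower number from compound 2 to compound 3 (1.05 log units; beyond the scatter) and thiophen-2-yl in place of 4-methylphenyl gives an at least 11-fold lower number from compound 1 to compound 3 (1.05 log units; beyond the scatter), so the exchange of a six-membered aromatic ring of carbon only for a five-membered aromatic ring with 1 hetero atom is the first change here with a readable outcome. Both steps are minimum sizes, since compound 1 and compound 2 each return only a limit and neither has a number of its own: the limit of > 32000 nM in this assay, at which 2 of the 3 values shown sit.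

The compounds shown do not separate the part played by the sulfur atom, by the ring size and by the loss of the chlorine or methyl group, as thiophen-2-yl differs from both earlier groups in all of these at once. An unsubstituted phenyl, a furan-2-yl or a thiophen-3-yl in the same place would bear on that question.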